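A Carboxy Group in Place of the Carbamoyl

The source may hold more compounds than are shown below. What is called first, only, known or untested is meant among the compounds shown, and "the series" means these compounds.

Measured so far in a functional assay on HepG2 cells (Homo sapiens) for cytotoxicity, read by MTT assay, with a stated time of 48 h; a lower number here means a stronger inhibitor, a higher number a weaker inhibitor:
Compound 1 `Cc1n[nH]c2c1C(c1ccc(N(C)C)cc1)C(C(=O)n1ncc(C#N)c1N)=C(N)N2` gives 66300 nM
Compound 2 `Cc1n[nH]c2c1C(c1ccc(N(C)C)cc1)C(C(N)=O)=C(N)N2` gives 5280 nM

Compound 2 holds the lower of the two numbers, and compound 1 stands above it by a margin beyond the scatter. The next compound to be measured is compound 3 `Cc1n[nH]c2c1C(c1ccc(N(C)C)cc1)C(C(=O)O)=C(N)N2`. Its difference from compound 2 is hydroxy in place of amino on a carbonyl carbon, which is hydroxy in place of amino on a carbonyl carbon, or carbamoyl to carboxy.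

For the measured compounds named here, one measured step bears on this change, because a 13-fold lower number from compound 1 to compound 2 (1.10 log units; beyond the scatter) also exchanged the group on that carbonyl carbon. That step was large, but the group it removed, 5-amino-4-cyano-1H-pyrazol-1-yl, is not the hydroxy that enters now, so it offers only a loose guide. Going by the values given here, the data hold no direct precedent for hydroxy at this place. A smaller step towards a higher number therefore seems the likeliest outcome, with the direction held only tentatively. The expected step is a 1.9-fold higher number from compound 2 to compound 3 (0.28 log units; within the scatter) in this assay. Compound 3 is estimated at 10000 nM, with an expected range from 2500 nM to 40000 nM.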

Compound 3, half-maximal inhibitory concentration: 39700 nM
Estimate against measurement, compound 3: 4.0-fold (0.60 log units) below; measured number inside the range.
By their numbers in this assay, from the lowest: compound 2; then compounds 3 and 1 (each within the scatter of the next).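

In this assay the new compound shows that this carbonyl carbon responds to an exchange far smaller than the earlier one: hydroxy in place of amino, each a single heavy atom with the same counted hydrogen-bond donor and acceptors, gives a 7.5-fold higher number from compound 2 to compound 3 (0.88 log units; beyond the scatter) and so undoes most of what the earlier step had gained. Set against the pyrazole-bearing compound, the carboxy compound gives a 1.7-fold lower number from compound 1 to compound 3 (0.22 log units; within the scatter), so hydroxy and 5-amino-4-cyano-1H-pyrazol-1-yl are not separated here, and amino alone, among the three groups shown on this carbon, stands apart from both others beyond the scatter. Nothing available explains why so small an exchange moves the number this far.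

The compounds shown leave open whether the low number of compound 2 survives on this carbonyl carbon with a methylamino or dimethylamino group, or with a methoxy group in place of the hydroxy. They also leave open whether a nitrile in place of the whole carbamoyl would read like compound 2 or like compound 3, and whether this order holds when the rest of the shared core changes.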